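From a Piperidine Thiocarbamate to Its Morpholine Counterpart

The source may hold more compounds than are shown below. What is called first, only, known or untested is meant among the compounds shown, and "the series" means these compounds.

These compounds share a core and differ in the amine attached to the thiocarbonyl carbon or in the group on the core. Compound 1 `COc1ccc2occ(CSC(=S)N3CCCCC3)c(=O)c2c1` carries piperidin-1-yl, and in a functional assay on HeLa cells (Homo sapiens) for antiproliferative activity, read by MTT assay, with a stated time of 72 h (a higher number here means a weaker inhibitor, a lower number a stronger inhibitor), compound 1 gives 3500 nM. Compound 3 `COc1ccc2occ(CSC(=S)N(C(C)C)C(C)C)c(=O)c2c1` carries diisopropylamino instead, and compound 3 gives 5400 nM; the step of a 1.5-fold higher number from compound 1 to compound 3 (0.19 log units; within the scatter) stays within the scatter. Compound 2 `O=c1cc(CSC(=S)N2CCCCC2)oc2cc(Cl)ccc12` keeps piperidin-1-yl on a chloro-bearing core. For compound 2 the assay reports only a limit, > 25000 nM, not a number. This is the same limit described as the limit of > 25000 nM in this assay, at which 1 of the 3 values shown sits.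

Compound 4 `O=c1cc(CSC(=S)N2CCOCC2)oc2cc(Cl)ccc12` differs from compound 2 in one place: morpholin-4-yl in place of piperidin-1-yl on a thiocarbonyl carbon. Among the measured compounds shown here, no measured step introduces morpholin-4-yl; the only change at the thiocarbonyl nitrogen, a 1.5-fold higher number from compound 1 to compound 3 (0.19 log units; within the scatter), produced no shift beyond scatter. With compound 2 already at a limit, compound 4 is expected to give 30000 nM, within a range from 10000 nM to 100000 nM. That corresponds to an expected step that the limit leaves unreadable from compound 2 to compound 4, most likely again reported only as a limit.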

Compound 4, half-maximal inhibitory concentration: 33300 nM
For compound 4 the middle estimate is 1.1-fold (0.05 log units) below the measured one; the range from low to high includes it.
By their numbers in this assay, from the lowest: compounds 1 and 3 (each within the scatter of the next); then compound 4.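

The step from compound 2 to compound 4 cannot be read, because compound 2 has a limit rather than a number: the limit of > 25000 nM in this assay, at which 1 of the 4 values shown sits.

The compounds shown leave open whether morpholin-4-yl in place of piperidin-1-yl on the thiocarbonyl carbon changes the antiproliferative number at all.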